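Removing the Methyl: Cytotoxicity Outlook for a Phenol Analogue

The source may hold more compounds than are shown below. What is called first, only, known or untested is meant among the compounds shown, and "the series" means these compounds.

The compounds in this study share one core and differ only in the group on the outer phenyl ring. Compound 1 `Fc1ccc(-c2nn3c(NC4CCCC4)nccc3c2-c2ccnc(NC3CCCC3)n2)cc1` carries a fluoro there, while compound 2 `COc1ccc(-c2nn3c(NC4CCCC4)nccc3c2-c2ccnc(NC3CCCC3)n2)cc1` carries a methoxy. In an ADME assay on Vero cells (Chlorocebus sabaeus) for cytotoxicity (on this read-out higher numbers stand for lower toxicity in this test and lower numbers for higher toxicity in this test), compound 1 gives > 40000 nM, which is a limit of the test rather than a measured number. In this assay compound 2 gives > 40000 nM, again a limit and not a number. The step that the two limits leave unreadable from compound 1 to compound 2 is therefore unreadable in size and direction; what the two values show is the limit of > 40000 nM in this assay, at which 2 of the 2 values shown sit, so compound 2 stands at that limit and nowhere more precise.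

Compound 3 `Oc1ccc(-c2nn3c(NC4CCCC4)nccc3c2-c2ccnc(NC3CCCC3)n2)cc1` is compound 2 with hydrogen in place of methyl on an oxygen on an aromatic ring. Going by the values given here, the only measured step concerns a different position and cannot be read, so it offers no basis for expecting a change beyond the scatter. The step of a number no higher from compound 2 to compound 3 (the limit leaves the size open) is accordingly expected to be none beyond the scatter. Compound 3 is therefore estimated to give about 40000 nM in this assay, within an expected range from 20000 nM to 80000 nM, with the test most likely again reporting only a limit.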

Compound 3, half-maximal cytotoxic concentration: 27000 nM
Compound 3: the middle estimate sits 1.5-fold (0.17 log units) above what was measured; low and high end bracket the measured number.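

Going by these compounds alone, compound 3, with its 4-hydroxyphenyl group, is the first compound here to give a true number rather than a limit: in this assay compound 3 gives 27000 nM, which shows that a change at this position can bring the read-out inside the range of the test. Hydrogen in place of methyl on the oxygen gives an at least 1.4-fold lower number from compound 2 to compound 3 (0.17 log units; that floor lies within the scatter), and hydroxy in place of fluoro gives an at least 1.4-fold lower number from compound 1 to compound 3 (0.17 log units; that floor lies within the scatter). Each of these is only a floor, so the true steps may be larger, but neither floor by itself shows a change beyond the usual scatter, and the remaining values offer no second number for comparison: the limit of > 40000 nM in this assay, at which 2 of the 3 values shown sit.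

The step between the fluoro and methoxy compounds cannot be read, so the size of any difference among the groups at this position remains uncertain. As far as these compounds go, whether a measurable number is particular to the hydroxy group, or would also appear with an amine or a carboxylic acid in its place, stays open.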